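The source may report more compounds than this note shows. Statements on the series, on what has been measured and on what is new or still open speak of the compounds shown alone.

Within the data shown here, compound 2 `C[C@H]1[C@H](N)CN1c1nc2c(cc1F)c(=O)c(C(=O)O)cn2C1CC1` gives 23 ug/mL in a physicochemical assay for solubility (a higher number here means a more soluble compound, a lower number a less soluble compound), the only true number so far. Compound 1 `C[C@H](N)C(=O)N[C@@H]1CN(c2nc3c(cc2F)c(=O)c(C(=O)O)cn3C2CC2)[C@H]1C` gives > 500 ug/mL in this assay, which is a limit of the assay and not a number.

Compound 3 `C[C@H](N)C(=O)N[C@@H](C)C(=O)N[C@@H]1CN(c2nc3c(cc2F)c(=O)c(C(=O)O)cn3C2CC2)[C@H]1C` is compound 2 with a new acyl group on the amine nitrogen: (1-(((1-aminoethyl)carbonyl)amino)ethyl)carbonyl in place of hydrogen on an amine nitrogen. The entering group, (1-(((1-aminoethyl)carbonyl)amino)ethyl)carbonyl, has no ring and no net charge.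

Among the measured compounds shown here, one measured step bears on this change: an at least 21-fold lower number from compound 1 to compound 2 (1.33 log units; beyond the scatter). It swaps (1-aminoethyl)carbonyl for hydrogen at the same amine nitrogen, so compound 3 reverses that direction with a different group. The size of that step is open at one end, as it rests on (the limit of > 500 ug/mL in this assay, at which 1 of the 2 values shown sits). With a single pair behind it, the read-across is tentative, and the reading for compound 3 may itself return only as a limit.

A large step to a higher number is expected in this assay. The expected change is a 26-fold higher number from compound 2 to compound 3 (1.42 log units; beyond the scatter). For compound 3 the estimate is 600 ug/mL, with an expected range of 200 ug/mL to 2000 ug/mL.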

Compound 3, solubility: > 500 ug/mL
Compound 3 gave a limit, no number; the forecaster's own chance of this, stated with the estimate: 60%; the middle value is on the limit's open side.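

Notes on the amine nitrogen whose other neighbours are a saturated ring carbon: a second acyl group, (1-(((1-aminoethyl)carbonyl)amino)ethyl)carbonyl, now gives a large move in this assay, with an at least 21-fold higher number from compound 2 to compound 3 (1.33 log units; beyond the scatter). The earlier pair showed this only for (1-aminoethyl)carbonyl, so in the compounds shown the move in this direction from the free amine no longer rests on one group, and the longer chain keeps the read-out at the top of what can be reported. The comparison of the two acyl groups, compound 1 against compound 3, cannot be read, and the step from compound 2 to compound 3 is open at its upper end: the limit of > 500 ug/mL in this assay, at which 2 of the 3 values shown sit.

Going by these compounds, whether the longer chain differs at all from the shorter one stays open, since neither has a true number in this assay and a ranking would need a value inside the range of the assay. Also open, on these data alone, is whether the terminal amine of these acyl groups matters, which a plain acetyl group on the same nitrogen would test against compound 2.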